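Cytotoxicity notes: aryl swap on the fused core

A few compounds are considered here, and "the series" means these few. Any claim that something is new, unique, unknown or untested is made for them only; others in the source may bear on it.

Measured in an ADME assay on HeLa cells (Homo sapiens) for cytotoxicity, read by ATP content, with a stated time of 3 days; a higher number here means that more compound is tolerated, a lower number that less compound is tolerated:
compound 1 `O=c1n(Cc2cc3ccncc3n2CCCCO)c2cnccc2n1C1CC1`: > 100000 nM
compound 2 `N#CCCCn1c(Cn2c(=O)n(-c3ccncn3)c3ccncc32)cc2cc(Cl)ccc21`: > 50000 nM
compound 3 `CC(C)CCn1c(Cn2c(=O)n(C3CC3)c3ccncc32)nc2nc(Cl)ccc21`: > 50000 nM

In this assay compound 2 is known only as a limit, > 50000 nM, not as a number. Compound 1 likewise reaches only a limit, > 100000 nM. Compound 3 also stops at a limit, > 50000 nM. So far nothing in the series has given a measurable half-maximal cytotoxic concentration: two of the three values sit at the limit of > 50000 nM in this assay, at which 2 of the 3 values shown sit, and the third at the limit of > 100000 nM in this assay, at which 1 of the 3 values shown sits. On the numbers shown, compound 2 therefore stands level with the other two, and no ordering among them can be read.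

The next compound, compound 4 `COc1ccc(-n2c(=O)n(Cc3cc4cc(Cl)ccc4n3CCCC#N)c3cnccc32)c(C)c1`, differs from compound 2 in one place: 4-methoxy-2-methylphenyl in place of pyrimidin-4-yl on an aromatic nitrogen. Among the compounds with values here, no measured step of this kind exists, so the expectation rests only on the limits already seen. With both neighbours in this assay at limits, the step from compound 2 to compound 4 is expected to be none beyond the scatter, a step that the limit leaves unreadable from compound 2 to compound 4, and compound 4 is most likely to return another limit rather than a number. The estimate for compound 4 in this assay is 60000 nM, expected to lie between 20000 nM and 150000 nM.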

Compound 4, half-maximal cytotoxic concentration: > 50000 nM
Compound 4: a limit, no number; the forecaster's own chance of this, stated with the estimate: 60%; the middle value is on the limit's open side.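

In this assay compound 4 gives > 50000 nM, which is a limit and not a number. Compound 2 is also known only as a limit, so no step can be read between compound 2 and compound 4. The compounds shown leave open whether 4-methoxy-2-methylphenyl and pyrimidin-4-yl differ at all in half-maximal cytotoxic concentration.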